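Capping the ring amine again: expected shift in cytotoxicity

This account rests on a few compounds, and the source may have more. Where it says the series, first, only, none or still open, it means among the compounds named here.

Of the compounds shown here, three that share one core have been tested in an ADME assay on MT4 cells (Homo sapiens) for cytotoxicity, read by MTT assay, with a stated time of 5 days; on this read-out lower numbers stand for higher toxicity in this test and higher numbers for lower toxicity in this test. Compound 3 `Cc1cc(/C=C/C#N)cc(C)c1Oc1nc(Nc2ccc(CN3CCNCC3)cc2)nc2sccc12` gives 4030 nM. Compound 2 `Cc1cc(/C=C/C#N)cc(C)c1Oc1nc(Nc2ccc(N3CCCC(N)C3)cc2)nc2sccc12` gives 4610 nM, and the step of a 1.1-fold lower number from compound 2 to compound 3 (0.06 log units; within the scatter) lies within the scatter, so these two stand together. Compound 1 `Cc1cc(/C=C/C#N)cc(C)c1Oc1nc(Nc2ccc(CN3CCN(S(C)(=O)=O)CC3)cc2)nc2sccc12` gives 131000 nM, far from both, as shown by a 33-fold lower number from compound 1 to compound 3 (1.51 log units; beyond the scatter) and a 28-fold lower number from compound 1 to compound 2 (1.45 log units; beyond the scatter). Compound 4 `Cc1cc(/C=C/C#N)cc(C)c1Oc1nc(Nc2ccc(N3CCCC(NS(N)(=O)=O)C3)cc2)nc2sccc12` differs from compound 3 in one place: 3-(sulfamoylamino)piperidin-1-yl in place of (piperazin-1-yl)methyl on an aromatic carbon. The step that bears on this is the one in which hydrogen replaced methylsulfonyl on the ring amine, a 33-fold lower number from compound 1 to compound 3 (1.51 log units; beyond the scatter); in compound 4 the amine carries a sulfamoyl group instead of hydrogen, so a large step toward higher numbers is expected. Compound 4 is therefore estimated at 60000 nM, with a range from 15000 nM to 200000 nM, an expected step of a 15-fold higher number from compound 3 to compound 4 (1.17 log units; beyond the scatter).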

Compound 4, half-maximal cytotoxic concentration: > 217000 nM
Compound 4 ended at the assay's limit; the forecaster's own chance of this, stated with the estimate: 20%; at least 3.6-fold (0.55 log units) between middle value and limit.
By their numbers in this assay, from the lowest: compounds 3 and 2 (each within the scatter of the next); then compound 1. At a limit, above all of these: compound 4.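

Going by these compounds alone, until now, capping had been seen only on the ring nitrogen of the (piperazin-1-yl)methyl group; on the 3-aminopiperidin-1-yl group, sulfamoyl in place of hydrogen on the amine nitrogen also brings a large rise, with an at least 47-fold higher number from compound 2 to compound 4 (1.67 log units; beyond the scatter). Exchanging the whole group gives an at least 53-fold higher number from compound 3 to compound 4 (1.73 log units; beyond the scatter), whereas the comparison between the two capped compounds gives an at least 1.6-fold higher number from compound 1 to compound 4 (0.21 log units; that floor lies within the scatter), so that gap stays unresolved. The reading for compound 4 is a limit of the assay, not a number: the limit of > 217000 nM in this assay, at which 1 of the 4 values shown sits.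

Still open, going by these compounds, is whether an acetyl group on the same amine nitrogen would raise the number as sulfamoyl does. Also open, on these data alone, is whether a longer chain between the amine and the piperidine ring would keep this effect.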